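Swapping the thiazole for a pyridine on the amide nitrogen

This account rests on a few compounds, and the source may have more. Where it says the series, first, only, none or still open, it means among the compounds named here.

The series comprises three measured compounds. Compound 1 `NCc1csc(NC(=O)c2cnn[nH]2)n1` gives -0.2 in a physicochemical assay for lipophilicity, read by HPLC, at pH 3.0; a higher number here means a more lipophilic compound, a lower number a more polar compound; compound 2 `NCc1csc(NC(=O)c2cc3ccccc3n2Cc2ccccc2)n1` gives 2.4 in the same assay. Compound 3 `Cc1csc(NC(=O)c2cc(C(C)(C)C)nn2Cc2ccccc2)n1` gives 4.7 and stands highest of the three numbers: its distance from compound 2 and from compound 1 lies in each case beyond the usual scatter of the measurement.

Compound 4 `CC(C)(C)c1cc(C(=O)Nc2ccncc2)n(Cc2ccccc2)n1` differs from compound 3 in one place (pyridin-4-yl in place of 4-methyl-1,3-thiazol-2-yl on an amide-type nitrogen). Among the compounds with values here, no pair of measured compounds shows this change, so its effect on this assay has to be judged without a directly comparable step.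

Given that the 4-methyl-1,3-thiazol-2-yl group leaves and a pyridin-4-yl group with one hydrogen-bond acceptor enters, compound 4 is expected to be a markedly more polar compound than compound 3, with a step of a number 2.70 log units lower from compound 3 to compound 4 (beyond the scatter). Compound 4 is therefore estimated at 2, with a range from 1 to 3.2.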

Compound 4, distribution coefficient: 2.6
Estimate against measurement, compound 4: 0.60 log units below, and the stated range covers the measured number.
By their numbers in this assay, from the lowest: compound 1; then compounds 2 and 4 (each within the scatter of the next); then compound 3.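

In this assay, the group on the amide-type nitrogen now has its first directly comparable step: pyridin-4-yl in place of 4-methyl-1,3-thiazol-2-yl gives a number 2.10 log units lower from compound 3 to compound 4 (beyond the scatter), a large change. The earlier compounds shown here differed from one another in more than one place, so they could not tie any change in the number to this position alone. Here the number moves strongly with the rest of the molecule held fixed and with the same count of heavy atoms entering and leaving, but nothing measured accounts for the size of this step.

The compounds shown leave open how a phenyl group or a pyridin-3-yl group on the same nitrogen would read. They also leave open whether the same swap would give a step of similar size on the core of compound 2.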